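From Cyclobutyl to Isopropyl on the Amide Nitrogen

This account rests on a few compounds, and the source may have more. Where it says the series, first, only, none or still open, it means among the compounds named here.

For the measured compounds named here, compound 2 `N[C@H]1CCC[C@@H](N(C(=O)c2ccccc2OCc2ccccc2)C2CCC2)C1` gives the lowest of the two numbers so far in an assay on HEK293 cells for inhibition of transient receptor potential cation channel subfamily M member 8 (Homo sapiens), read by FLIPR and calcium flux (a higher number here means a weaker inhibitor, a lower number a stronger inhibitor), 794 nM. Compound 1 `CCCN(C(=O)c1ccccc1OCc1ccccc1)[C@@H]1CCC[C@H](N)C1` gives 1430 nM in this assay. The step of a 1.8-fold lower number from compound 1 to compound 2 (0.26 log units; within the scatter) lies within the scatter. Compound 3 `CC(C)N(C(=O)c1ccccc1OCc1ccccc1)[C@@H]1CCC[C@H](N)C1` carries isopropyl in place of cyclobutyl on an amide-type nitrogen. Going by the values given here, the only step that bears on this change is the earlier move from propyl to cyclobutyl, a 1.8-fold lower number from compound 1 to compound 2 (0.26 log units; within the scatter), which was small. Compound 3 is therefore expected to show only a 1.3-fold higher number from compound 2 to compound 3 (0.10 log units; within the scatter), a shift within the scatter. Compound 3 is estimated to give 1000 nM in this assay, within 400 nM to 2500 nM.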

Compound 3, antagonist equilibrium constant: 5130 nM
For compound 3 the middle estimate is 5.1-fold (0.71 log units) below the measured one; the whole stated range lies below it.
By their numbers in this assay, from the lowest: compounds 2 and 1 (each within the scatter of the next); then compound 3.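

In this assay, the group on this amide-type nitrogen can shift the number beyond the scatter: isopropyl stands apart from cyclobutyl (a 6.5-fold higher number from compound 2 to compound 3 (0.81 log units; beyond the scatter)) and from propyl (a 3.6-fold higher number from compound 1 to compound 3 (0.55 log units; beyond the scatter)). Propyl and cyclobutyl had stayed within the scatter of each other, so this position does not treat all small carbon groups alike, and the higher number comes with isopropyl, the only one of the three branched at that nitrogen. Nothing available here gives a reason for this. As far as these compounds go, it remains open whether cyclopropyl or tert-butyl on the same nitrogen would fall with isopropyl or with cyclobutyl. From the compounds shown here alone, whether an ethyl group would stay with propyl is equally open.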